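This account rests on a few compounds, and the source may have more. Where it says the series, first, only, none or still open, it means among the compounds named here.

Measured so far in a functional assay on the whole organism for antagonist activity, with Mus musculus as the target, in the maximal electroshock model (on this read-out lower numbers stand for an effect already at smaller amounts and higher numbers for an effect only at larger amounts of compound), with every value a limit of the assay:

- compound 1 `CC[S+]([O-])c1nnc(-c2ccccc2)n1C` gives > 200 mg/kg as a limit
- compound 2 `COc1ccc(-c2nnc(S(C)(=O)=O)n2C)cc1` gives > 200 mg/kg as a limit
- compound 3 `CSc1nc(-c2ccccc2)n(C)n1` gives > 100 mg/kg as a limit

Compound 3 stands at > 100 mg/kg and this is a limit, not a number. Compound 4 `Cn1nc([S+](C)[O-])nc1-c1ccccc1` is not yet measured. The change leading to it is a group of 3 heavy atoms (1 carbon, 1 oxygen, 1 sulfur; no ring) in place of a group of 2 heavy atoms (1 carbon, 1 sulfur; no ring), on an aromatic carbon and it falls on an aromatic carbon of a five-membered aromatic ring with 3 nitrogen, where methylsulfanyl leaves. For the measured compounds named here, no step between measured compounds gives a size to go by. Compound 1 also has oxygen on its sulfur, and its > 200 mg/kg is a limit. Compound 2 has oxygen on its sulfur too, and its > 200 mg/kg is a limit. The expected step that the limit leaves unreadable from compound 3 to compound 4 is estimated to stay within the usual scatter, with no direction favoured. The estimated value for compound 4 is 150 mg/kg with 60 mg/kg to 400 mg/kg as the expected range. A report as a limit alone is expected to be more likely than a number.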

Compound 4, dose for half-maximal effect: > 200 mg/kg
Compound 4 ended at the assay's limit (the forecaster's own chance of this, stated with the estimate: 70%); middle value at least 1.3-fold (0.12 log units) from the limit.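

In this assay compound 3 and compound 4 both stand at limits, so the step between them cannot be read. The compounds shown leave open whether oxygen on the sulfur changes the dose for half-maximal effect, and in which direction.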